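Swapping the amide ring in a pancreatic cell growth assay

A few compounds are considered here, and "the series" means these few. Any claim that something is new, unique, unknown or untested is made for them only; others in the source may bear on it.

Compound 2 `CCN(CC)S(=O)(=O)c1ccc(S(=O)(=O)N2CCC[C@@H](C(=O)N3CCC(F)(F)CC3)C2)cc1` is the stronger of the two compounds measured in a functional assay on BXPC-3 cells (Homo sapiens) for inhibition, read by MTT assay, with a stated time of 7 days; on this read-out higher numbers stand for weaker inhibition and lower numbers for stronger inhibition: compound 2 gives 120 nM, while compound 1 `CCN(CC)S(=O)(=O)c1ccc(S(=O)(=O)N2CCC[C@@H](C(=O)N3CCC(C(F)(F)F)CC3)C2)cc1` gives 370 nM. Among the compounds with values here, that step, a 3.1-fold lower number from compound 1 to compound 2 (0.49 log units; beyond the scatter), is the only comparison at hand. Compound 3 `CCN(CC)S(=O)(=O)c1ccc(S(=O)(=O)N2CCC[C@@H](C(=O)N3CC[C@H](OC)C3)C2)cc1` differs from compound 2 by 3-methoxypyrrolidin-1-yl in place of 4,4-difluoropiperidin-1-yl on a carbonyl carbon. Within the data shown here, no measured step makes this particular change, so the known step from compound 1 to compound 2 bears on it only loosely: it shows that the group on the carbonyl carbon can shift the number by a modest amount in this assay. From the compounds shown here alone, exchanging the six-membered ring for a five-membered one carrying a methoxy group is untested here, so the expected outcome is a step of a 2.1-fold higher number from compound 2 to compound 3 (0.32 log units; beyond the scatter) toward a weaker number, with wide uncertainty. Compound 3 is estimated at 250 nM, within a range from 80 nM to 800 nM.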

Compound 3, half-maximal inhibitory concentration: 6750 nM
For compound 3 the middle estimate is 27-fold (1.43 log units) below the measured one; the whole stated range lies below it.
By their numbers in this assay, from the lowest: compound 2; then compound 1; then compound 3.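

The group on the carbonyl carbon matters far more in this assay than the first pair could show: 3-methoxypyrrolidin-1-yl in place of 4,4-difluoropiperidin-1-yl gives a large loss of strength (a 56-fold higher number from compound 2 to compound 3 (1.75 log units; beyond the scatter)), well past the modest earlier step. The same group also falls well short of 4-(trifluoromethyl)piperidin-1-yl (an 18-fold higher number from compound 1 to compound 3 (1.26 log units; beyond the scatter)), so compound 3 is weaker than both compounds with a fluorinated six-membered ring. No measurement at hand explains this loss.

This change swaps the ring size and the ring's substituent together, so the compounds shown cannot tell which of the two carries the loss. A 4-methoxypiperidin-1-yl or a 3,3-difluoropyrrolidin-1-yl group on the same carbonyl carbon would pull those two changes apart.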